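This account rests on a few compounds, and the source may have more. Where it says the series, first, only, none or still open, it means among the compounds named here.

Compound 1 `CCc1cccc(NC(=O)c2cccc(/C=C3\CC(=O)N(Cc4ccccc4)C3=O)c2)c1` gives > 100000 nM in an ADME assay on NCM460 cells (Homo sapiens) for cytotoxicity, read by MTT assay, with a stated time of 72 h (a lower number here means a stronger inhibitor, a higher number a weaker inhibitor), which is a limit of the assay.
Compound 2 `CCc1cccc(NC(=O)c2cccc(/C=C3\CC(=O)N(c4ccccc4)C3=O)c2)c1` gives > 100000 nM in this assay, which is again a limit of the assay.

In this assay, among the compounds with values here, compound 2 therefore stands only at a limit, not at a number, and the same is true of the only other measured compound, since (the limit of > 100000 nM in this assay, at which 2 of the 2 values shown sit). Within the data shown here, the one measured step, a step that the two limits leave unreadable from compound 1 to compound 2, puts phenyl in place of benzyl on the ring nitrogen and cannot be read in size or direction from two limits.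

Compound 3 `CCCCCN1C(=O)C/C(=C\c2cccc(C(=O)Nc3cccc(CC)c3)c2)C1=O` follows from compound 2 by the change (pentyl in place of phenyl on an amide-type nitrogen in a ring). Among the measured compounds shown here, no measured step concerns a pentyl group, and the single step available, from compound 1 to compound 2, bears on the same nitrogen but is unreadable. Nothing measured points to a step beyond the scatter, and with both neighbours at the limit the expectation for compound 3 remains at that limit. The step is thus expected to be a step that the limit leaves unreadable from compound 2 to compound 3, essentially none beyond the scatter. Compound 3 is expected at about 150000 nM, in the range 50000 nM to 500000 nM, most probably reported again only as a limit.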

Compound 3, half-maximal inhibitory concentration: > 100000 nM
Compound 3: a limit, no number; the forecaster's own chance of this, stated with the estimate: 85%; the middle value lies beyond the limit too.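

No step among compound 1, compound 2 and compound 3 can be read in this assay, since all three stand at a limit of the assay and not at a number: the limit of > 100000 nM in this assay, at which 3 of the 3 values shown sit.

The compounds shown leave open how benzyl, phenyl and pentyl on the amide-type nitrogen in the ring compare, and what number, if any, each would give in this assay.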